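Macrocyclic hydroxamic acids: amide to amine linker change

This account rests on a few compounds, and the source may have more. Where it says the series, first, only, none or still open, it means among the compounds named here.

Compound 1 `O=C(CCCCC(=O)N1C/C=C/CCOc2cccc(c2)-c2ccnc(n2)Nc2cccc(c2)C1)NO` gives 1010 nM in a functional assay on MV4-11 cells (Homo sapiens) for inhibition, read by CellTiter-Glo, with a stated time of 48 h; a lower number here means a stronger inhibitor of growth, a higher number a weaker inhibitor of growth. Within the data shown here, compound 2 `O=C(CCCCCCC(=O)N1C/C=C/COCc2cccc(c2)-c2ccnc(n2)Nc2cccc(c2)C1)NO` gives 1410 nM in this assay; the gap to compound 1 is within the scatter, so the two compounds stand together on the numbers so far. Compound 3 `O=C(CCCCCCN1C/C=C/COCc2cccc(c2)-c2ccnc(n2)Nc2cccc(c2)C1)NO` is not yet measured. It differs from compound 2 in one place: 6-(hydroxycarbamoyl)hexyl in place of (6-(hydroxycarbamoyl)hexyl)carbonyl on an amine nitrogen in a ring. Among the measured compounds shown here, no measured pair shows this change, so the expectation rests on the two values alone. A modest rise in number is expected, a 1.4-fold higher number from compound 2 to compound 3 (0.15 log units; within the scatter), with wide uncertainty. Compound 3 is thus estimated at 2000 nM, range 600 nM to 7000 nM.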

Compound 3, concentration for 50% growth inhibition: 320 nM
For compound 3 the middle estimate is 6.3-fold (0.80 log units) above the measured one, and the stated range ends above it.
By their numbers in this assay, from the lowest: compound 3; then compounds 1 and 2 (each within the scatter of the next).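

Among these compounds, on the amine nitrogen in the ring, 6-(hydroxycarbamoyl)hexyl in place of (6-(hydroxycarbamoyl)hexyl)carbonyl gives a 4.4-fold lower number from compound 2 to compound 3 (0.64 log units; beyond the scatter) in this assay and so provides the first step beyond the scatter. The carbonyl on this nitrogen therefore matters to growth inhibition in this pair, which the earlier values alone could not show. Nothing available explains the size of this step.

Going by these compounds, whether the same change holds on the core of compound 1 remains open. Also open, on these data alone, is how a longer chain, or a carboxylic acid in place of the hydroxycarbamoyl end, would read on this nitrogen.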